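Fluoro for hydrogen on the pendant ring of compound 3

The source may report more compounds than this note shows. Statements on the series, on what has been measured and on what is new or still open speak of the compounds shown alone.

Compound 3 `c1ccc(Cn2cnc3c(Sc4ccccc4)ncnc32)cc1` sits lowest of the three numbers available in an assay on isolated protein for inhibition of Rho-associated protein kinase 1 (Homo sapiens), tested at 30 uM; a higher number here means more inhibition at the concentration tested (going by the name of the read-out), a lower number less inhibition: compound 3 gives 1%. Compound 2 `Cn1cnc2c(Sc3ccc(F)cc3)ncnc21` is its nearest neighbour; compound 2 gives 6%, a gap that lies within the scatter, so no order between compound 2 and compound 3 can be claimed. Compound 1 `Fc1ccc(Sc2ncnc3[nH]cnc23)cc1` is furthest away and gives 37%, a gap that lies beyond the scatter. Going by the values given here, the one step between measured compounds that differ in a single place, a number 31 percentage points lower from compound 1 to compound 2 (beyond the scatter), concerns methyl in place of hydrogen on an aromatic nitrogen and is large.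

Compound 4 `Fc1ccc(Sc2ncnc3c2ncn3Cc2ccccc2)cc1` differs from compound 3 by fluoro in place of hydrogen on an aromatic carbon. Among the compounds with values here, no measured pair isolates this change: compound 1 and compound 2 both already carry the fluoro, and compound 3 differs from each of them in more than one place. The methyl step therefore does not bear on the present change, and nothing in the series shows that a fluoro on this ring moves this assay. The expected step is none beyond the scatter, written as a number 3 percentage points higher from compound 3 to compound 4 (within the scatter). For compound 4 the estimate in this assay is 4%, with a range from 0% to 15%.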

Compound 4, a percentage reported as inhibition, at one concentration (the size of the read-out at that concentration, not a potency): 5%
For compound 4 the middle estimate is 1 percentage points below the measured one, and the stated range covers the measured number.
By their numbers in this assay, from the lowest: compounds 3, 4 and 2 (each within the scatter of the next); then compound 1.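

With a benzyl group on the aromatic nitrogen, the change from phenylsulfanyl to (4-fluorophenyl)sulfanyl can now be read directly: in this assay it gives a number 4 percentage points higher from compound 3 to compound 4 (within the scatter), so this pair shows no effect of the fluoro on that six-membered aromatic ring. With the fluoro held constant, phenyl in place of hydrogen on the saturated chain carbon gives a number 1 percentage points lower from compound 2 to compound 4 (within the scatter), which does not separate benzyl from methyl on the aromatic nitrogen, whereas benzyl in place of hydrogen on that nitrogen gives a number 32 percentage points lower from compound 1 to compound 4 (beyond the scatter), so both substituents, read with a number 31 percentage points lower from compound 1 to compound 2 (beyond the scatter), stand beyond the scatter from the compound bearing hydrogen there. No measured property or other supporting finding bears on these steps.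

Whether the fluoro matters when hydrogen stays on the aromatic nitrogen remains open, as the compounds shown hold no pair isolating that change on the more inhibiting compound 1 scaffold. Also open, as far as these compounds go, is how this assay responds to an amine or a carboxylic acid on the pendant ring, or to a longer chain on the aromatic nitrogen.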